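This account rests on a few compounds, and the source may have more. Where it says the series, first, only, none or still open, it means among the compounds named here.

Compound 1 `CCSc1ccc(C2CC(=O)N2c2cc(OC)c(OC)c(OC)c2)cc1` and compound 2 `COc1ccc(C2CC(=O)N2c2cc(OC)c(OC)c(OC)c2)cc1O` share one core. In a functional assay on HT-29 cells (Homo sapiens) for inhibition, read by sulforhodamine B assay, with a stated time of 72 h (on this read-out lower numbers stand for stronger inhibition and higher numbers for weaker inhibition), compound 1 gives 311 nM, and compound 2 gives 521 nM; the two numbers lie within the usual scatter of each other, so neither is set apart. Compound 3 `COc1ccc(C2CC(=O)N2c2cc(OC)c(OC)c(OC)c2)cc1` has not been measured; it differs from compound 2 by hydrogen in place of hydroxy on an aromatic carbon. Among the compounds with values here, no measured pair shows this change, so the expected step is modest: compound 3 is expected to give 220 nM in this assay, within 60 nM to 800 nM, which means an expected step of a 2.4-fold lower number from compound 2 to compound 3 (0.37 log units; beyond the scatter), a lower number, at the edge of the scatter.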

Compound 3, half-maximal inhibitory concentration: 65 nM
Beside the measured number, compound 3's estimate is 3.4-fold (0.53 log units) above it; low and high end bracket the measured number.
By their numbers in this assay, from the lowest: compound 3; then compounds 1 and 2 (each within the scatter of the next).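

In this assay, hydrogen in place of the hydroxy ortho to a methoxy group gives an 8.0-fold lower number from compound 2 to compound 3 (0.90 log units; beyond the scatter) at this aromatic carbon, a clear gain that compounds 1 and 2, lying within the scatter of each other, could not reveal. Methoxy in place of ethylsulfanyl on an aromatic carbon gives a 4.8-fold lower number from compound 1 to compound 3 (0.68 log units; beyond the scatter), so compound 3 stands apart from both earlier compounds. Nothing available explains either step. Going by these compounds, whether an amine or a fluorine atom on the carbon that carried the hydroxy would match hydrogen remains open, as does how a longer chain such as propoxy would compare with the methoxy of compound 3.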